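A few compounds are considered here, and "the series" means these few. Any claim that something is new, unique, unknown or untested is made for them only; others in the source may bear on it.

Compound 1, `O=C1NC(=O)/C(=C/c2ccc(OCc3csc(-c4ccccc4)n3)cc2)S1`, gives 25.2% in a functional assay on the whole organism (strain Wistar) with Rattus norvegicus as the target, with a stated time of 15 days, at a dose of 3 mg/kg by the oral route; a lower number here means a weaker effect, a higher number a stronger effect of the compound at the dose given.
Compound 2, `O=C1NC(=O)/C(=C/c2ccc(OCCSc3nnc(Cc4ccccc4)[nH]3)cc2)S1`, gives 22.5% in this assay.
Compound 3, `Cc1ccc(-c2nnc(SCCOc3ccc(/C=C4\SC(=O)NC4=O)cc3)[nH]2)cc1`, gives 25.2% in this assay.

The three numbers are close. Compound 2 gives the smallest of them in this assay, but compound 1 and compound 3 each lie within the usual scatter of it, so the three compounds cannot be told apart on these data.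

Compound 4, `O=C1NC(=O)/C(=C/c2ccc(OCCSc3nnc(-c4ccccc4[N+](=O)[O-])[nH]3)cc2)S1`, is not yet measured in this assay. It differs from compound 2 in one place: 2-nitrophenyl in place of benzyl on an aromatic carbon.

For the measured compounds named here, one measured step bears on this change, since it touches the same aromatic carbon of compound 2: a number 2.7 percentage points higher from compound 2 to compound 3 (within the scatter). That exchange of one carbon ring for another at this position left the read-out in this assay unchanged within the scatter. Going by the values given here, no measured compound carries a nitro group, so the data give no direct guide to that part of the change, and the step from compound 2 to compound 4 is therefore expected to stay within the scatter as well.

Compound 4 is therefore estimated to give about 24% in this assay, with a range from 14% to 34%. The estimate implies a step of a number 1.5 percentage points higher from compound 2 to compound 4 (within the scatter), which is expected to lie within the scatter.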

Compound 4, a percentage reported as activity, at one dose (the size of the read-out at that dose, not a potency): 19.8%
For compound 4 the middle estimate is 4.2 percentage points above the measured one; measured number inside the range.
By their numbers in this assay, from the lowest: compounds 4, 2, 1 and 3 (each within the scatter of the next).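

In this assay the exchange of benzyl for 2-nitrophenyl, on the aromatic carbon between two ring nitrogen atoms, gives a number 2.7 percentage points lower from compound 2 to compound 4 (within the scatter) and the exchange of 4-methylphenyl for the same group gives a number 5.4 percentage points lower from compound 3 to compound 4 (within the scatter) so neither step separates the compounds. For the compounds shown here, this position now carries three different groups in compounds 2, 3 and 4, and the entry of a nitro group, with the hydrogen-bond acceptors counted for it, brings no step beyond the scatter, which the single earlier step at this carbon could not show. The data offer no measured explanation of why the read-out stays so flat across these groups.

As far as these compounds go, all three groups at this carbon contain a six-membered aromatic ring of carbon only, so it remains open whether an amine, a carboxylic acid or a longer chain in that place would move the read-out beyond the scatter. From the compounds shown here alone, it also remains open whether 4-nitrophenyl would read like 2-nitrophenyl, and whether the compounds would separate at a dose other than the single one tested here.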